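Chlorophenyl ester series: antiproliferative working notes

The compounds below may be only part of what the source reports. "The series", "measured", "known", "first", "only" and "open" are said of these compounds alone.

Measured so far in a functional assay on HCT-15 cells (Homo sapiens) for antiproliferative activity, read by sulforhodamine B assay, with a stated time of 48 h, tested at 50 uM; on this read-out lower numbers stand for less inhibition and higher numbers for more inhibition at the one concentration tested (going by the name of the read-out):
compound 1 `Cc1cc2c(C(C)C)ccc(C)c2cc1OC(=O)c1cccc(C(F)(F)F)c1`: "not active" (no number reported)
compound 2 `CC1=CC[C@H](C(C)C)c2cc(C)c(OC(=O)c3ccc(Cl)cc3)cc21`: 47.4%
compound 3 `COc1ccc(C(=O)Oc2cc3c(C)ccc(C(C)C)c3cc2C)cc1`: 84%

Compound 2 holds the lower of the two numbers given; compound 3 lies higher by a margin beyond the usual scatter, and for compound 1 no number is reported, only the absence of activity. Compound 4 `CC1=CC[C@H](C(C)C)c2cc(C)c(OC(=O)c3cccc(Cl)c3)cc21` is not yet measured. It differs from compound 2 in one place: 3-chlorophenyl in place of 4-chlorophenyl on a carbonyl carbon. Within the data shown here, no measured pair shows this kind of change, so the size of the step is unknown; compound 1 carries a different group on the ester and a different core, which gives no firm guide. A step of no more than modest size downward, or none beyond the scatter, is expected, a number 7.4 percentage points lower from compound 2 to compound 4 (within the scatter). For compound 4 the estimate in this assay is 40%, within 15% to 65%.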

Compound 4, a percentage reported as inhibition, at one concentration (the size of the read-out at that concentration, not a potency): 5.3%
Compound 4: the middle estimate sits 34.7 percentage points above what was measured, and the stated range ends above it.
By their numbers in this assay, from the lowest: compound 4; then compound 2; then compound 3.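

In this assay, 3-chlorophenyl in place of 4-chlorophenyl on the carbonyl carbon gives a number 42.1 percentage points lower from compound 2 to compound 4 (beyond the scatter), so the read-out at this place depends strongly on where the chlorine sits on the ring. Among these compounds, no earlier pair isolated such a change, and here the atoms are the same and only their joining differs. Nothing measured on these compounds accounts for the drop.

On these data alone, whether an amine or a carboxylic acid in place of the chlorine would restore inhibition stays open. So does whether the same change would act alike on the core of compound 3.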